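Removing the Chloro Group From a Thiophene Urea

This account rests on a few compounds, and the source may have more. Where it says the series, first, only, none or still open, it means among the compounds named here.

Compound 1 `CN1CC(=O)N/C1=N\C(=O)Nc1csc(Cl)c1` was examined in a functional assay for antagonist activity at metabotropic glutamate receptor 5 (Homo sapiens), read by FLIPR (a higher number here means a weaker inhibitor, a lower number a stronger inhibitor), where compound 1 gives 434 nM. For the measured compounds named here, the only other compound measured there, compound 2 `Cc1cccc(C#Cc2ccncc2)n1`, is built on an unrelated scaffold; in this assay compound 2 gives 213 nM. On these two numbers compound 1 stands as the higher of the pair, with compound 2 returning a number lower by a margin beyond the usual scatter. Compound 3 `CN1CC(=O)N/C1=N\C(=O)Nc1ccsc1` has not yet been measured. It differs from compound 1 in one place: hydrogen in place of chloro on an aromatic carbon, next to the ring sulfur. Going by the values given here, no measured pair shows what this change does here, so any expectation rests on general experience with such removals. The step from compound 1 to compound 3 in this assay is expected to raise the number, a 3.5-fold higher number from compound 1 to compound 3 (0.54 log units; beyond the scatter). For compound 3 the estimate is 1500 nM, with a range from 500 nM to 5000 nM.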

Compound 3, half-maximal inhibitory concentration: 4020 nM
For compound 3 the middle estimate is 2.7-fold (0.43 log units) below the measured one; low and high end bracket the measured number.
By their numbers in this assay, from the lowest: compound 2; then compound 1; then compound 3.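

In this assay, for the compounds shown here, the replacement of chloro by hydrogen gives a 9.3-fold higher number from compound 1 to compound 3 (0.97 log units; beyond the scatter) and so provides the first measured reading of this position, on an aromatic carbon next to the ring sulfur. On the core of compound 1, the single chlorine atom therefore makes a difference well beyond the scatter, with the stronger inhibitor being the compound that carries it. No available measurement explains the size or direction of this shift.

The compounds shown cannot tell whether chlorine is specifically required at this place or whether bromo, methyl or a nitrile would give a similar number. They also leave open whether the same step would have a similar size with a change elsewhere on the shared core, such as an ethyl group in place of the methyl.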